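A few compounds are considered here, and "the series" means these few. Any claim that something is new, unique, unknown or untested is made for them only; others in the source may bear on it.

Measured compounds:
compound 1 `CCCCCc1ccc(C#Cc2c(-c3ccc(CCCCC)cc3)oc3nc(=O)n(Cc4cn(-c5ccccc5F)nn4)cc23)cc1` — 9000 nM
compound 2 `CCCCCCc1cc2cn(Cc3cn(-c4ccccc4F)nn3)c(=O)nc2o1` — > 100000 nM
compound 3 `O=c1nc2oc(CCCCl)cc2cn1Cc1cn(-c2ccc(F)cc2)nn1` — 6990 nM

In a functional assay on HeLa cells (Homo sapiens) for antiproliferative activity, read by MTT assay, with a stated time of 72 h (on this read-out higher numbers stand for weaker inhibition and lower numbers for stronger inhibition), compound 1 gives 9000 nM. Of the two numbers measured this is the higher, yet compound 3, with 6990 nM, lies within the usual scatter of it, so the two cannot be ranked against each other. Compound 2 reaches only a limit of the assay, > 100000 nM, and gives no number (the limit of > 100000 nM in this assay, at which 1 of the 3 values shown sits).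

Compound 4 `CCCCCc1ccc(C#Cc2c(-c3ccc(CCCCC)cc3)oc3nc(=O)n(Cc4cn(Cc5ccccc5)nn4)cc23)cc1` differs from compound 1 in a single place: benzyl in place of 2-fluorophenyl on an aromatic nitrogen. Within the data shown here, no pair of measured compounds shows this exchange, so nothing here measures what it does; the groups that leave and enter are alike in their count of heavy atoms, donors and acceptors. The expectation for compound 4 is therefore a step of no change at the digits printed from compound 1 to compound 4 (within the scatter) of no size beyond the scatter, in neither direction. Compound 4 is estimated at 9000 nM, within a range from 3000 nM to 27000 nM.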

Compound 4, half-maximal inhibitory concentration: 73000 nM
The estimate for compound 4 lay 8.1-fold (0.91 log units) below the measured number, outside the stated range (above it).
By their numbers in this assay, from the lowest: compounds 3 and 1 (each within the scatter of the next); then compound 4. At a limit, above all of these: compound 2.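

In this assay, among these compounds, benzyl in place of 2-fluorophenyl on an aromatic nitrogen brings an 8.1-fold higher number from compound 1 to compound 4 (0.91 log units; beyond the scatter), which shows that the number responds to the group at this position, something the earlier compounds did not test. The leaving and entering groups have the same counts of heavy atoms, hydrogen-bond donors and hydrogen-bond acceptors, so a match in these counts did not keep the number in place. Nothing shown here gives a reason for this step.

The compounds shown leave open whether a plain phenyl on this nitrogen would give a number closer to that of compound 1 or that of compound 4, and the same question stands for 2-fluorobenzyl. As far as these compounds go, it also remains open how a hexyl chain at this position would compare with either group.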